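A few compounds are considered here, and "the series" means these few. Any claim that something is new, unique, unknown or untested is made for them only; others in the source may bear on it.

Measured so far:
compound 1 `Nc1ccccc1NC(=O)c1ccc(CSC(=S)N2CCCc3ccccc32)cc1` gives 81.5% in a functional assay on A-375 cells (Homo sapiens) for antiproliferative activity, read by CCK-8 assay, with a stated time of 72 h, tested at 8 uM; a higher number here means a stronger effect of the compound at the concentration tested, a lower number a weaker effect
compound 2 `CC1CCN(C(=S)SCc2ccc(C(=O)Nc3ccccc3N)cc2)CC1` gives 87.4% in this assay

Going by the values given here, compound 2 holds the larger of the two numbers so far, but the only measured step, a number 5.9 percentage points higher from compound 1 to compound 2 (within the scatter), lies within the usual scatter, so compound 1 and compound 2 are not separated by these data. That step exchanged one amine on the thiocarbonyl carbon for another and left the rest of the shared core untouched.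

Compound 3 `CN(Cc1cccnc1)C(=S)SCc1ccc(C(=O)Nc2ccccc2N)cc1` is the next member, and it changes the same position: methyl((pyridin-3-yl)methyl)amino in place of 4-methylpiperidin-1-yl on a thiocarbonyl carbon. Among the compounds with values here, the one step that bears on it, a number 5.9 percentage points higher from compound 1 to compound 2 (within the scatter), shows that swapping the amine on the thiocarbonyl carbon between two ring amines moved the number by an amount inside the scatter. Compound 3 brings an open-chain amine carrying an aromatic ring in place of a saturated ring, a wider change than the measured one, yet nothing here shows that this position is sensitive, so no step beyond the scatter is expected in this assay.

For compound 3 the estimate in this assay is therefore 80%, within 65% to 92%, which means an expected step of a number 7.4 percentage points lower from compound 2 to compound 3 (within the scatter).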

Compound 3, a percentage reported as inhibition, at one concentration (the size of the read-out at that concentration, not a potency): 83.8%
Compound 3: the middle estimate sits 3.8 percentage points below what was measured; the range from low to high includes it.
By their numbers in this assay, from the lowest: compounds 1, 3 and 2 (each within the scatter of the next).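

Exchanging the saturated ring amine 4-methylpiperidin-1-yl for the open-chain methyl((pyridin-3-yl)methyl)amino, which adds an aromatic ring and a hydrogen-bond acceptor on the thiocarbonyl carbon, gives in this assay a number 3.6 percentage points lower from compound 2 to compound 3 (within the scatter), and the exchange from 1,2,3,4-tetrahydroquinolin-1-yl gives a number 2.3 percentage points higher from compound 1 to compound 3 (within the scatter). Going by these compounds alone, the earlier step compared only two ring amines; these steps extend the finding to an open-chain amine, so compound 1, compound 2 and compound 3 are all within the scatter of one another and this wider change does not separate them. No measurement available here accounts for this lack of separation.

As far as these compounds go, whether a morpholin-4-yl group, or an amine carrying a carboxylic acid, on the thiocarbonyl carbon would also stay within the scatter of these three compounds remains open. From the compounds shown here alone, the read-out is the size of the effect at one concentration rather than a potency, so compounds that are not separated here could still differ in potency, and the effect of changes elsewhere on the shared core also remains open.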